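Enlarging the Alkyl Group on the Aryl Urea

A few compounds are considered here, and "the series" means these few. Any claim that something is new, unique, unknown or untested is made for them only; others in the source may bear on it.

Measured so far:
Compound 1 `Cc1ccc(NC(=O)N[C@@H](C)c2ccccc2)cc1` gives 100% in an ADME assay on the whole organism with Oryza sativa as the target, tested at 10 uM; a higher number here means a weaker effect of the compound at the concentration tested, a lower number a stronger effect.
Compound 2 `CC(C)c1ccc(NC(=O)N[C@@H](C)c2ccccc2)cc1` gives 86% in this assay.

Compound 2 stands lowest of the two numbers; its nearest neighbour is compound 1, separated by a number 14 percentage points lower from compound 1 to compound 2 (beyond the scatter), the step that accompanies isopropyl in place of methyl on an aromatic carbon. Compound 3 `C[C@H](NC(=O)Nc1ccc(C(C)(C)C)cc1)c1ccccc1` is not yet measured. It differs from compound 2 by methyl in place of hydrogen on a saturated chain carbon bound to an aromatic carbon and two saturated chain carbons. Within the data shown here, only that one measured step bears on this change, since it too enlarged the same group, and it was modest. A further lowering of similar or somewhat smaller size is therefore expected, a number 10 percentage points lower from compound 2 to compound 3 (within the scatter). Compound 3 is estimated at 76%, between 60% and 92%.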

Compound 3, a percentage reported as activity, at one concentration (the size of the read-out at that concentration, not a potency): 64%
Estimate against measurement, compound 3: 12 percentage points above, and the stated range covers the measured number.
By their numbers in this assay, from the lowest: compound 3; then compound 2; then compound 1.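

In this assay the change from isopropyl to tert-butyl brings a number 22 percentage points lower from compound 2 to compound 3 (beyond the scatter) and so shows that the lowering does not stop at isopropyl. Taken whole, tert-butyl in place of methyl gives a number 36 percentage points lower from compound 1 to compound 3 (beyond the scatter) and makes this the large step of the series, with all three compounds falling in order as the alkyl group grows. No measurement shown gives a reason for this fall. Still open, on these data alone, is whether a longer chain or a cyclohexyl ring at this place would lower the number further, or whether only branched alkyl groups do so. A methoxy group or an amine there is also untested ground among the compounds shown.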